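Methylating the phenol in a naphthyl analogue

This account rests on a few compounds, and the source may have more. Where it says the series, first, only, none or still open, it means among the compounds named here.

In a functional assay on Ehrlich cells (Mus musculus) for cytotoxicity, read by trypan blue exclusion, with a stated time of 2 h, tested at 10 ug/mL (a higher number here means a stronger effect of the compound at the concentration tested, a lower number a weaker effect), compound 1 `N#CC1=C(N)N(c2ccc(S(N)(=O)=O)cc2)C2=C(CCCC2)C1c1ccc(O)cc1` gives 20%. Compound 2 `COc1ccc(C2C(C#N)=C(N)N(c3ccc(S(N)(=O)=O)cc3)C3=C2CCCC3)cc1` carries methyl in place of hydrogen on an oxygen on an aromatic ring and in this assay compound 2 gives 50%, a step of a number 30 percentage points higher from compound 1 to compound 2 (beyond the scatter). Compound 3 `N#CC1=C(N)N(c2ccc(S(N)(=O)=O)cc2)C2=C(CCCC2)C1c1c(O)ccc2ccccc12` differs from compound 1 by 2-hydroxynaphthalen-1-yl in place of 4-hydroxyphenyl on a saturated ring carbon; in this assay compound 3 gives 10%, with a number 10 percentage points lower from compound 1 to compound 3 (within the scatter) and a number 40 percentage points lower from compound 2 to compound 3 (beyond the scatter). Compound 4 `COc1ccc2ccccc2c1C1C(C#N)=C(N)N(c2ccc(S(N)(=O)=O)cc2)C2=C1CCCC2` has not yet been measured; it differs from compound 3 by methyl in place of hydrogen on an oxygen on an aromatic ring, the same change at the same place as in the pair already measured. That earlier step raised the read-out by a number 30 percentage points higher from compound 1 to compound 2 (beyond the scatter). Among the measured compounds shown here, the expected step is a number 25 percentage points higher from compound 3 to compound 4 (beyond the scatter), because a number 30 percentage points higher from compound 1 to compound 2 (beyond the scatter) is the only precedent here, and the cores differ. Compound 4 is estimated at 35%, between 10% and 60%.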

Compound 4, a percentage reported as activity, at one concentration (the size of the read-out at that concentration, not a potency): 5%
Beside the measured number, compound 4's estimate is 30 percentage points above it; the measured number lies below the stated range.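

In this assay, changing hydroxy to methoxy on the core of compound 3 gives a number 5 percentage points lower from compound 3 to compound 4 (within the scatter), so the rise seen on the core of compound 1 does not recur. The same change therefore does not carry over between these two cores, as the two steps show: the same change on two cores in this assay, a number 30 percentage points higher (beyond the scatter) from compound 1 to compound 2 and a number 5 percentage points lower (within the scatter) from compound 3 to compound 4, 35 percentage points apart, beyond the scatter of two such steps

Among the compounds shown here, this rests on only two pairs; it does not show why the steps differ, or how the change would behave on any other core.

The compounds shown leave open whether an ethoxy group, a longer chain on that oxygen, or an amine in place of the hydroxy group would shift the read-out on either core. Read at a single concentration, these numbers show only a stronger or weaker effect at that concentration.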